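The source may hold more compounds than are shown below. What is called first, only, known or untested is meant among the compounds shown, and "the series" means these compounds.

Working notes on the series in an ADME assay on cells (Splenocyte, Mus musculus, strain BALB/c) for cytotoxicity, read by CCK-8 assay, with a stated time of 48 h; on this read-out higher numbers stand for lower toxicity in this test and lower numbers for higher toxicity in this test.

Compound 1, `COc1cc(-c2noc(-c3ccccc3)n2)cc(OC)c1OC`, is recorded in this assay only as a limit, > 50000 nM. Compound 2, `CCCCc1ccc(-c2nc(-c3cc(OC)c(OC)c(OC)c3)no2)cc1`, gives 21200 nM in this assay. For the measured compounds named here, compound 2 therefore holds the only actual number in the set; the one other value is a limit, as summarised by the limit of > 50000 nM in this assay, at which 1 of the 2 values shown sits. Going by the values given here, the single measured step, an at least 2.3-fold lower number from compound 1 to compound 2 (0.37 log units; beyond the scatter), is the only comparison available, and it points to more toxicity in this test once a chain is present on the aromatic carbon.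

Compound 3, `CCCCCCc1ccc(-c2nc(-c3cc(OC)c(OC)c(OC)c3)no2)cc1`, is not yet measured. Compared with compound 2 the change is ethyl in place of hydrogen on a saturated chain carbon, four bonds along the chain from an aromatic carbon. Among the compounds with values here, this is a further lengthening of the same chain whose introduction gave the one measured step, so that step is the only bearing evidence, and it was at least modest in size. A step of similar direction but smaller size is expected here, within a wide range given the single reference point.

The estimated step is a 1.8-fold lower number from compound 2 to compound 3 (0.25 log units; within the scatter). Compound 3 is therefore expected to give about 12000 nM in this assay, within 5000 nM to 30000 nM.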

Compound 3, half-maximal cytotoxic concentration: 25000 nM
Compound 3: middle estimate off by 2.1-fold (0.32 log units), on the low side; the range from low to high includes it.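

Ethyl in place of hydrogen on a saturated chain carbon, four bonds along the chain from an aromatic carbon, gives a 1.2-fold higher number from compound 2 to compound 3 (0.07 log units; within the scatter) in this assay, so butyl and hexyl cannot be told apart here, and lengthening the chain at this position adds no readable change beyond what butyl already showed. The hexyl chain of compound 3 measured against the bare aromatic carbon of compound 1 gives an at least 2.0-fold lower number from compound 1 to compound 3 (0.30 log units; that floor lies within the scatter), so this comparison with the unsubstituted compound does not clear the scatter at its floor, even though the butyl step did. Compound 1 is recorded only as a limit, so neither step from it has a fixed size: the limit of > 50000 nM in this assay, at which 1 of the 3 values shown sits.

Going by these compounds, it remains open whether an octyl chain would give a number beyond the scatter of compound 2 and compound 3, or whether a chain carrying an amine or a carboxylic acid would give a number closer to the limit of compound 1. Also open, on these data alone, is whether a propyl chain would already give a number like that of compound 2, which would locate more closely where the chain begins to count.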